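From 4-methylbenzyl to 3,4-dichlorobenzyl in compound 4

This account rests on a few compounds, and the source may have more. Where it says the series, first, only, none or still open, it means among the compounds named here.

- compound 1 `CCN(CC)Cc1ccc2nc(NC(=O)N/N=C/c3cn(Cc4ccc(C)cc4)c4ccccc34)sc2c1` gives 1510 nM
- compound 2 `Cc1ccc(Cn2cc(/C=N/NC(=O)Nc3nc4ccc(CN5CCC(C)CC5)cc4s3)c3ccccc32)cc1` gives 2180 nM
- compound 3 `Cc1ccc(Cn2cc(/C=N/NC(=O)Nc3nc4ccc(CN(C)C)cc4s3)c3ccccc32)cc1` gives 1600 nM

In a functional assay on A549 cells (Homo sapiens) for cytotoxicity, read by MTT assay, with a stated time of 72 h (a higher number here means a weaker inhibitor, a lower number a stronger inhibitor), compound 1 gives 1510 nM, and it cannot be separated from the other two measured compounds. The steps show a 1.4-fold higher number from compound 1 to compound 2 (0.16 log units; within the scatter) and a 1.1-fold higher number from compound 1 to compound 3 (0.03 log units; within the scatter), and the remaining pair shows a 1.4-fold lower number from compound 2 to compound 3 (0.13 log units; within the scatter). All three steps exchange the amine on a saturated chain carbon bound to an aromatic carbon, and across these exchanges the numbers stay level.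

The next compound, compound 4 `CCN(CC)Cc1ccc2nc(NC(=O)N/N=C/c3cn(Cc4ccc(Cl)c(Cl)c4)c4ccccc34)sc2c1`, keeps the diethylamino group of compound 1 and changes the other end of the molecule: 3,4-dichlorophenyl in place of 4-methylphenyl on a saturated chain carbon bound to an aromatic nitrogen. In words, 3,4-dichlorophenyl stands in place of 4-methylphenyl on a saturated chain carbon bound to an aromatic nitrogen. Going by the values given here, no measured step touches this place, so the data give no direct guide to its size or direction. The amine steps, such as a 1.4-fold higher number from compound 1 to compound 2 (0.16 log units; within the scatter), bear on it only loosely, as a sign of how little the series has moved so far.

No shift beyond the scatter is therefore expected, though the uncertainty is wide. The expected outcome is a 1.2-fold lower number from compound 1 to compound 4 (0.07 log units; within the scatter). For compound 4 the estimated value in this assay is 1300 nM, with an expected range from 400 nM to 3800 nM.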

Compound 4, half-maximal inhibitory concentration: 1470 nM
The estimate for compound 4 lay 1.1-fold (0.05 log units) below the measured number; measured number inside the range.
By their numbers in this assay, from the lowest: compounds 4, 1, 3 and 2 (each within the scatter of the next).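

The earlier compounds shown here varied only the amine, so they said nothing about the other end of the molecule. In this assay, 3,4-dichlorophenyl in place of 4-methylphenyl on a saturated chain carbon bound to an aromatic nitrogen gives a 1.0-fold lower number from compound 1 to compound 4 (0.01 log units; within the scatter), which shows that this second position also tolerates a change with the number staying level, and that a methyl group can give way to two chlorine atoms on the phenyl ring without a shift beyond the scatter. Nothing available explains why the number holds level at this position.

From the compounds shown here alone, the 3,4-dichlorobenzyl group appears here only with diethylamino, so it remains open whether the number would also hold level with dimethylamino or 4-methylpiperidin-1-yl at the amine end. Going by these compounds, a single exchange also says little about how far this position can be pushed, and it remains open whether the numbers would stay level with an amine or a carboxylic acid on the phenyl ring, or with a longer chain such as hexyl in place of the benzyl group.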